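Compound 2 and the untested aryl change

The compounds below may be only part of what the source reports. "The series", "measured", "known", "first", "only" and "open" are said of these compounds alone.

Compound 1 `COc1cc(-c2nc(-c3ccccc3)[nH]c2-c2ccnc(NCCCNS(=O)(=O)c3ccc(C(F)(F)F)cc3)n2)ccc1Cl`: 1780 nM
Compound 2 `COc1cc(-c2nc(-c3ccccc3)[nH]c2-c2ccnc(NCCCNS(=O)(=O)c3cccc(F)c3)n2)ccc1Cl`: 5110 nM
Compound 3 `COc1ccc(S(=O)(=O)NCCCNc2nccc(-c3[nH]c(-c4ccccc4)nc3-c3ccc(Cl)c(OC)c3)n2)cc1`: 1800 nM

All three values come from a functional assay on LOX IMVI cells (Homo sapiens) for cytotoxicity, read by MTT assay, with a stated time of 24 h (on this read-out higher numbers stand for weaker inhibition and lower numbers for stronger inhibition), and compound 2 has the highest number of the set. The unmeasured compound 4 `O=S(=O)(NCCCNc1nccc(-c2[nH]c(-c3ccccc3)nc2-c2ccc(F)c(O)c2)n1)c1cccc(F)c1` keeps the 3-fluorophenyl on the sulfonyl sulfur of compound 2 but alters another place: 4-fluoro-3-hydroxyphenyl in place of 4-chloro-3-methoxyphenyl on an aromatic carbon. For the measured compounds named here, no measured step touches that place. The nearest guides are changes on the sulfonyl sulfur: a 2.9-fold higher number from compound 1 to compound 2 (0.46 log units; beyond the scatter) and a 2.8-fold lower number from compound 2 to compound 3 (0.45 log units; beyond the scatter), both modest, and a 1.0-fold higher number from compound 1 to compound 3 (0.00 log units; within the scatter), within the scatter. They suggest the size of step to expect but give no direction, so no clear shift beyond the scatter is expected. The estimated change is a 1.5-fold lower number from compound 2 to compound 4 (0.16 log units; within the scatter). For compound 4 the estimate is 3500 nM, with an expected range from 1200 nM to 10000 nM.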

Compound 4, half-maximal inhibitory concentration: 7890 nM
Beside the measured number, compound 4's estimate is 2.3-fold (0.35 log units) below it; low and high end bracket the measured number.
By their numbers in this assay, from the lowest: compounds 1 and 3 (each within the scatter of the next); then compounds 2 and 4 (each within the scatter of the next).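

For the compounds shown here, the only step at this place, on an aromatic carbon of a five-membered aromatic ring with 2 nitrogen, gives in this assay a 1.5-fold higher number from compound 2 to compound 4 (0.19 log units; within the scatter). With the 3-fluorophenyl held on the sulfonyl sulfur, the two aryl groups are therefore not told apart, even though the entering group carries a hydrogen-bond donor that the leaving group lacks. No evidence at hand bears on this result.

The fluorine for chlorine and hydroxy for methoxy changes travel together, so neither can be read alone. From the compounds shown here alone, whether an amine or a carboxylic acid on this aryl ring would shift the number stays open.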